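Exchanging the Side Chain of Compound 3

The source may hold more compounds than are shown below. What is called first, only, known or untested is meant among the compounds shown, and "the series" means these compounds.

In a functional assay on MDA-MB-231 cells (Homo sapiens) for cytotoxicity, read by MTT assay, with a stated time of 72 h (on this read-out higher numbers stand for weaker inhibition and lower numbers for stronger inhibition), compound 3 `CN1CCN(CCCCCCn2c3c(c4ccccc42)C(=O)c2c[n+]([O-])c4ccccc4c2C3=O)CC1` gives 2400 nM. Compound 2 `O=C1c2c[n+]([O-])c3ccccc3c2C(=O)c2c1c1ccccc1n2Cc1cn(C[C@H](O)CO)nn1` gives 1310 nM, and a 1.8-fold higher number from compound 2 to compound 3 (0.26 log units; within the scatter) leaves the two values together. Compound 1 `O=C1c2c[n+]([O-])c3ccccc3c2C(=O)c2c1c1ccccc1n2CCCCn1ccnc1` gives 210 nM, and it stands well apart from both, with a 6.2-fold higher number from compound 1 to compound 2 (0.80 log units; beyond the scatter) and an 11-fold higher number from compound 1 to compound 3 (1.06 log units; beyond the scatter).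

Compound 4 `O=C1c2c[n+]([O-])c3ccccc3c2C(=O)c2c1c1ccccc1n2CCCN1CCC(O)CC1` differs from compound 3 by one exchange: 4-hydroxypiperidin-1-yl in place of 3-(4-methylpiperazin-1-yl)propyl on a saturated chain carbon, three bonds along the chain from an aromatic nitrogen, on a saturated chain carbon, three bonds along the chain from an aromatic nitrogen. Going by the values given here, no measured step makes this exact exchange, so the three steps above serve only as a rough guide to how far a change in this chain can move the number. They span a result within the scatter and a large shift, and none of the three compounds gives a number clearly above compound 3. A modest move towards lower numbers is therefore expected. The estimated change is a 2.4-fold lower number from compound 3 to compound 4 (0.38 log units; beyond the scatter). For compound 4, the expected value is 1000 nM, with an estimated range from 300 nM to 3000 nM.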

Compound 4, half-maximal inhibitory concentration: 280 nM
For compound 4 the middle estimate is 3.6-fold (0.55 log units) above the measured one; the measured number lies below the stated range.
By their numbers in this assay, from the lowest: compounds 1 and 4 (each within the scatter of the next); then compounds 2 and 3 (each within the scatter of the next).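

The exchange of 3-(4-methylpiperazin-1-yl)propyl for 4-hydroxypiperidin-1-yl gives an 8.6-fold lower number from compound 3 to compound 4 (0.93 log units; beyond the scatter) and so shows that a chain ending in a saturated six-membered ring can reach low numbers at this position, which neither compound 2 nor compound 3 had shown. Going by these compounds alone, the same holds against the triazole chain, with a 4.7-fold lower number from compound 2 to compound 4 (0.67 log units; beyond the scatter) in this series, while a 1.3-fold higher number from compound 1 to compound 4 (0.12 log units; within the scatter) within the scatter shows that the 1H-imidazol-1-yl end of compound 1 is not the only group that reaches this level. No measurement shown here bears on why the number falls at this position.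

As far as these compounds go, the step changes the chain and its end together, as 5-(4-methylpiperazin-1-yl)pentyl becomes 2-(4-hydroxypiperidin-1-yl)ethyl, so the share of each remains open. From the compounds shown here alone, it also remains open whether the hydroxyl matters, which a plain piperidin-1-yl or a morpholin-4-yl on the same chain would test.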